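Swapping the biaryl arm of a cytotoxicity-free series

A few compounds are considered here, and "the series" means these few. Any claim that something is new, unique, unknown or untested is made for them only; others in the source may bear on it.

Compound 3 `CCOC(=O)CCCCCOc1cccc(CN(C(=O)c2ccc(-c3ccc(C(C)=O)s3)cc2)C(C)C)c1` is one of three compounds tested in an ADME assay on HEK293 cells (Homo sapiens) for cytotoxicity, read by CellTiter-Glo and resazurin assay, with a stated time of 72 h; a lower number here means that less compound is needed, a higher number that more compound is needed for the effect. Compound 1 `COc1ccc(F)c(-c2ccc(C(=O)N(Cc3cccc(OCCCCCC(=O)O)c3)C(C)C)cc2)c1` gives only a limit, > 26000 nM. Compound 2 `CCOC(=O)CCCCCOc1cccc(CN(C(=O)c2ccc(-c3cccc(N(C)C)c3)cc2)C(C)C)c1` likewise stops at a limit, > 26000 nM. Compound 3 too shows nothing but a limit, > 26000 nM. Going by the values given here, because all three sit at the limit of > 26000 nM in this assay, at which 3 of the 3 values shown sit, no compound can be ranked against another, and the one comparison that exists, a step that the two limits leave unreadable from compound 2 to compound 3, cannot be read for size or direction.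

Compound 4 `CCOC(=O)CCCCCOc1cccc(CN(C(=O)c2ccc(-c3cc(OC)ccc3F)cc2)C(C)C)c1` differs from compound 3 in one place: 2-fluoro-5-methoxyphenyl in place of 5-acetylthiophen-2-yl on an aromatic carbon. The entering group is the same aromatic arm carried by compound 1. Compound 1, with that arm, also gave only a limit, > 26000 nM, and this is the main guide. Among the compounds with values here, no measured step offers a readable size, so the expectation rests on every compound so far having stayed at the limit. The step from compound 3 to compound 4 is therefore expected to be a step that the limit leaves unreadable from compound 3 to compound 4, that is, no change beyond the scatter. Compound 4 is estimated to give 40000 nM in this assay, within a range from 20000 nM to 100000 nM, and most likely to be reported once more only as a limit.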

Compound 4, half-maximal effective concentration: > 26000 nM
Compound 4 gave a limit, no number (the forecaster's own chance of this, stated with the estimate: 85%); the middle value lies beyond the limit too.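

Compound 4, like compounds 1, 2 and 3, gives only a limit in this assay, so none of its steps from those three compounds can be read for size or direction: the limit of > 26000 nM in this assay, at which 4 of the 4 values shown sit.

The compounds shown leave open whether any change to the aromatic arm or the ethyl group would yield a measurable number in this assay.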